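Compound 3 to compound 4: chloro gives way to nitro

A few compounds are considered here, and "the series" means these few. Any claim that something is new, unique, unknown or untested is made for them only; others in the source may bear on it.

Measured in a functional assay on RS4-11 cells (Homo sapiens) for inhibition, read by CCK-8 assay, with a stated time of 48 h; on this read-out lower numbers stand for stronger inhibition and higher numbers for weaker inhibition:
Compound 1 `COc1ccc(Oc2ccccc2-c2ccsc2S(=O)(=O)N2CCN(C(=S)Nc3ccc([N+](=O)[O-])cc3)CC2)cc1OC`: > 50000 nM (a limit of the assay)
Compound 2 `O=C(Nc1ccc(F)cc1)N1CCN(S(=O)(=O)c2sccc2-c2ccccc2Oc2ccc(O)c(O)c2)CC1`: 6800 nM
Compound 3 `O=S(=O)(c1sccc1-c1ccccc1Oc1ccc(O)c(O)c1)N1CCN(C(=S)Nc2ccc(Cl)cc2)CC1`: 7500 nM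

Within the data shown here, only two of these readings are numbers, and compound 3 stands level with compound 2 on them: a 1.1-fold higher number from compound 2 to compound 3 (0.04 log units; within the scatter). Compound 1 gives a limit and not a number: the limit of > 50000 nM in this assay, at which 1 of the 3 values shown sits.

The next compound, compound 4 `O=[N+]([O-])c1ccc(NC(=S)N2CCN(S(=O)(=O)c3sccc3-c3ccccc3Oc3ccc(O)c(O)c3)CC2)cc1`, keeps everything in compound 3 except one group, with nitro in place of chloro on an aromatic carbon. Among the measured compounds shown here, no measured step makes this exchange directly. For the measured compounds named here, the nearest evidence is the one step available, a 1.1-fold higher number from compound 2 to compound 3 (0.04 log units; within the scatter), in which the whole group on the ring nitrogen changed and this assay did not move beyond the scatter. Going by the values given here, compound 1 also carries 4-nitrophenyl, but its reading is a limit and so gives no size of step. On this thin basis, no shift beyond the scatter is expected, though the range has to stay wide. The expected change is a 1.1-fold lower number from compound 3 to compound 4 (0.03 log units; within the scatter). Compound 4 is estimated at 7000 nM, with an expected range of 2500 nM to 20000 nM.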

Compound 4, half-maximal inhibitory concentration: 9000 nM
For compound 4 the middle estimate is 1.3-fold (0.11 log units) below the measured one; low and high end bracket the measured number.
By their numbers in this assay, from the lowest: compounds 2, 3 and 4 (each within the scatter of the next). At a limit, above all of these: compound 1.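

In this assay, nitro in place of chloro on an aromatic carbon, para to a large group, now has a directly measured step, and it does not move the reading beyond the scatter: a 1.2-fold higher number from compound 3 to compound 4 (0.08 log units; within the scatter). The same holds when the whole group on the ring nitrogen differs, a 1.3-fold higher number from compound 2 to compound 4 (0.12 log units; within the scatter), so at this position 4-chlorophenyl and 4-nitrophenyl read alike and compounds 2, 3 and 4 stand level. Compound 4 also gives the first step that pairs the 4-nitrophenyl group with a change at the other end of the molecule, 3,4-dihydroxyphenyl in place of 3,4-dimethoxyphenyl, and this step lies beyond the scatter, an at least 5.5-fold lower number from compound 1 to compound 4 (0.74 log units; beyond the scatter), though the reading of compound 1 is a limit and not a number: the limit of > 50000 nM in this assay, at which 1 of the 4 values shown sits.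

What the compounds shown leave open is whether an amine or a carboxylic acid on the same aromatic carbon would also stay level with chloro and nitro. They also leave open whether the step from 3,4-dimethoxyphenyl to 3,4-dihydroxyphenyl would have a similar size with 4-chlorophenyl in place of 4-nitrophenyl.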